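The source may hold more compounds than are shown below. What is called first, only, known or untested is meant among the compounds shown, and "the series" means these compounds.

Measured in a functional assay on SH-SY5Y cells (Homo sapiens) for cytotoxicity, read by MTT assay, with a stated time of 72 h; a higher number here means a weaker inhibitor, a lower number a stronger inhibitor:
Compound 1, `CN1CCN(CCCCCCn2c3c(c4ccccc42)C(=O)c2c[n+]([O-])c4ccccc4c2C3=O)CC1`: 920 nM
Compound 2, `O=C1c2c[n+]([O-])c3ccccc3c2C(=O)c2c1c1ccccc1n2Cc1cn([C@H]2C[C@H](O)[C@@H](CO)O2)nn1`: 620 nM
Compound 3, `O=C1c2c[n+]([O-])c3ccccc3c2C(=O)c2c1c1ccccc1n2Cc1cn([C@@H]2C[C@H](O)[C@@H](CO)O2)nn1`: 150 nM

Among these three, compound 1 gives the highest number in this assay; compound 2 sits within the scatter of it, while compound 3 lies beyond the scatter below it. Within the data shown here, the only step between measured compounds, a 4.1-fold lower number from compound 2 to compound 3 (0.62 log units; beyond the scatter), rests on the fact that compounds 2 and 3 differ only in the configuration as drawn and concerns a stereocentre on a side chain of a different kind. It therefore has no bearing on the change to compound 4, `O=C1c2c[n+]([O-])c3ccccc3c2C(=O)c2c1c1ccccc1n2CCCCN1CCNCC1`, which carries piperazin-1-yl in place of 2-(4-methylpiperazin-1-yl)ethyl on a saturated chain carbon, four bonds along the chain from an aromatic nitrogen. Among the measured compounds shown here, no measured pair addresses this exchange on the chain, so no step beyond the scatter is expected in this assay. The step expected is a 1.0-fold lower number from compound 1 to compound 4 (0.01 log units; within the scatter). Compound 4 is therefore estimated at 900 nM, with a range from 350 nM to 2500 nM.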

Compound 4, half-maximal inhibitory concentration: 1240 nM
Estimate against measurement, compound 4: 1.4-fold (0.14 log units) below, and the stated range covers the measured number.
By their numbers in this assay, from the lowest: compound 3; then compounds 2, 1 and 4 (each within the scatter of the next).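

In this assay, replacing 2-(4-methylpiperazin-1-yl)ethyl with piperazin-1-yl on a saturated chain carbon, four bonds along the chain from an aromatic nitrogen, gives a 1.3-fold higher number from compound 1 to compound 4 (0.13 log units; within the scatter) and so stays within the scatter. Among these compounds, this is the first measured step at this position, and it shows that this exchange on the chain leaves the number essentially unmoved. Nothing in the available evidence bears on this exchange.

From the compounds shown here alone, the step shortens the chain and removes the ring methyl together, so the effect of each alone remains open. Also open, going by these compounds, is whether a morpholine or a carboxylic acid at the chain end would give a step beyond the scatter.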